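A few compounds are considered here, and "the series" means these few. Any claim that something is new, unique, unknown or untested is made for them only; others in the source may bear on it.

The study rests on an in vitro ADME assay on microsomes from liver (Homo sapiens) for metabolic stability; on this read-out lower numbers stand for slow clearance and higher numbers for fast clearance. Compound 1 `Cc1ncc(Cc2nc(-c3nc(C(F)(F)F)n[nH]3)n3ccccc23)cn1` gives a reading that is a limit of the assay rather than a number, < 8 mL.min-1.g-1. Compound 2 `Cc1ncc(Cn2nc(-c3nc(C(F)(F)F)n[nH]3)c3cccnc32)cn1` likewise returns only a limit, < 7 mL.min-1.g-1. Going by the values given here, compound 3 `Fc1ccccc1Cc1nc(-c2ncn[nH]2)n2ccccc12` is the one compound of the three with a numbered result in this assay, where compound 3 gives 175 mL.min-1.g-1, a reading at the fast-clearance end of this read-out. Among the compounds with values here, no pair of measured compounds differing in a single place has been worked out here, so no measured step is available to lean on.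

Compound 4 `CS(=O)(=O)c1n[nH]c(-c2nc(Cc3ccccc3F)c3ccccn23)n1` has not yet been measured. It differs from compound 3 in one place: methylsulfonyl in place of hydrogen on an aromatic carbon.

For compound 4 the expectation in this assay is a step downward, toward slower clearance and beyond the usual scatter, of roughly a 3.5-fold lower number from compound 3 to compound 4 (0.54 log units; beyond the scatter). Compound 4 is accordingly estimated to give 50 mL.min-1.g-1, with the likely range running from 15 mL.min-1.g-1 to 150 mL.min-1.g-1.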

Compound 4, intrinsic clearance in microsomes: 11 mL.min-1.g-1
Compound 4: middle estimate off by 4.5-fold (0.66 log units), on the high side, and the stated range ends above it.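

Until now no single change could be followed, and here methylsulfonyl in place of hydrogen on an aromatic carbon gives a 16-fold lower number from compound 3 to compound 4 (1.20 log units; beyond the scatter) in this assay. This carbon, between two ring nitrogen atoms of the five-membered aromatic ring, is therefore a place where one exchange can move a compound a long way from the fast-clearance end of the read-out. Nothing shown here explains why the number falls so far.

On these data alone, only hydrogen and methylsulfonyl can be compared at this carbon, so it remains open whether a nitrile, an amine or a carboxylic acid there would bring a similar step. As far as these compounds go, compound 1 and compound 2 carry trifluoromethyl at this carbon but differ from compound 3 in more than one place, so the effect of that group alone also remains open.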